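This account rests on a few compounds, and the source may have more. Where it says the series, first, only, none or still open, it means among the compounds named here.

Measured compounds:
- compound 1, `COc1ccc(-c2cc(/C=C/C(=O)c3ccc(C)c(C)c3)nc3cc(-c4ccccc4)nn23)cc1OC`, in an ADME assay on HEK293 cells (Homo sapiens) for antiproliferative activity, read by MTT assay, with a stated time of 24 h (on this read-out higher numbers stand for weaker inhibition and lower numbers for stronger inhibition), compound 1 gives 46200 nM
- compound 2, `COc1ccc(C(=O)/C=C/c2cc(-c3ccc(OC)cc3)n3nc(-c4ccccc4)cc3n2)cc1`, in this assay compound 2 gives 36100 nM
- compound 3, `COc1cc(-c2cc(/C=C/C(=O)c3ccc(C)c(C)c3)nc3cc(-c4ccccc4)nn23)cc(OC)c1OC`, in this assay compound 3 gives 72500 nM

Compound 3 and compound 1 differ in a single place: hydrogen in place of methoxy on an aromatic carbon. That change gave a step of a 1.6-fold lower number from compound 3 to compound 1 (0.20 log units; within the scatter), so on this read-out the two compounds cannot be told apart with confidence. Compound 2 and compound 3 differ in more than one place, and the difference between the two cores is not broken down here. The numbers for compound 2, compound 1 and compound 3 all lie within the scatter of one another, so none of the three is called the strongest or the weakest.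

Compound 4, `COc1ccc(-c2cc(/C=C/C(=O)c3ccccc3)nc3cc(-c4ccccc4)nn23)cc1`, has not yet been measured. It differs from compound 2 in one place: hydrogen in place of methoxy on an aromatic carbon. Among the measured compounds shown here, this is the same kind of change as the one from compound 3 to compound 1, but not the same: there the carbon sat ortho to a methoxy group, meta to a large group and meta to a methoxy group, while here it sits para to a large group. For the measured compounds named here, because the only measured example of this change gave a 1.6-fold lower number from compound 3 to compound 1 (0.20 log units; within the scatter), the step from compound 2 to compound 4 is expected to be small as well, about a 1.1-fold lower number from compound 2 to compound 4 (0.03 log units; within the scatter), resting on the number for compound 2 of 36100 nM. Compound 4 is therefore estimated at 34000 nM, with a likely range from 15000 nM to 80000 nM.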

Compound 4, half-maximal inhibitory concentration: 53200 nM
Beside the measured number, compound 4's estimate is 1.6-fold (0.19 log units) below it; low and high end bracket the measured number.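

In this assay, putting hydrogen in place of methoxy para to a large group gave a 1.5-fold higher number from compound 2 to compound 4 (0.17 log units; within the scatter), so on this read-out the two compounds cannot be told apart with confidence. Set beside the only other example of this change, the result does not show that the two cores respond differently: the same change on two cores in this assay, a 1.6-fold lower number (0.20 log units; within the scatter) from compound 3 to compound 1 and a 1.5-fold higher number (0.17 log units; within the scatter) from compound 2 to compound 4, 2.3-fold (0.36 log units) apart, within the scatter of two such steps. This shows that in both of these pairs the swap of methoxy for hydrogen left the numbers within the usual scatter, but two pairs, with the change made at different places on the ring, cannot show that the change is without effect in general or that the step on one core predicts the step on another.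

From the compounds shown here alone, it remains open whether a different group at the same place, such as an amine, a carboxylic acid or a chain longer than methoxy, would give a step that stands clear of the scatter. Going by these compounds, it is also open whether the swap of methoxy for hydrogen would read the same way on other cores or in other cells.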